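Swapping Methoxy for Fluoro on a Weak Inhibitor

This account rests on a few compounds, and the source may have more. Where it says the series, first, only, none or still open, it means among the compounds named here.

Of the compounds shown here, two sharing one core have been tested in a functional assay on HCT-116 cells (Homo sapiens) for antiproliferative activity, read by MTT assay, with a stated time of 48 h; a higher number here means a weaker inhibitor, a lower number a stronger inhibitor. Compound 1 `Cc1cnc(Nc2ccc(S(N)(=O)=O)cc2)nc1Nc1nc2ccccc2s1` carries a phenyl ring bearing a sulfonamide, and in this assay compound 1 gives 1660 nM. Compound 2 `COc1cccc(Nc2ncc(C)c(Nc3nc4ccccc4s3)n2)c1` instead carries a 3-methoxyphenyl ring. For compound 2 the result in this assay is only a limit, > 50000 nM, so compound 2 has no single number. Its reading sits at the limit of > 50000 nM in this assay, at which 1 of the 2 values shown sits, and of the two values shown it is the one that lies at the limit.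

Compound 3 `Cc1cnc(Nc2cccc(F)c2)nc1Nc1nc2ccccc2s1` has not yet been measured. It differs from compound 2 in one place: fluoro in place of methoxy on an aromatic carbon. Among the measured compounds shown here, no step between two measured compounds of this kind is available, so the expectation rests on compound 2 alone. Exchanging one small substituent for another is not expected to move the compound far from where compound 2 lies, so compound 3 is expected to remain a weak inhibitor. The expected step of an at least 1.2-fold lower number from compound 2 to compound 3 (0.09 log units; that floor lies within the scatter) is thus small, if any. Compound 3 is estimated at 40000 nM, in a range from 8000 nM to 100000 nM.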

Compound 3, half-maximal inhibitory concentration: 27800 nM
Estimate against measurement, compound 3: 1.4-fold (0.16 log units) above; low and high end bracket the measured number.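

Of the compounds shown, compound 3 is the one with a small single substituent on this ring, meta to a large group, that reads as an actual number: in this assay compound 3 gives 27800 nM. Compound 2 stands only as a limit and not as a number: the limit of > 50000 nM in this assay, at which 1 of the 3 values shown sits. Replacing methoxy, with its two heavy atoms, by fluoro, with its one, therefore gives an at least 1.7-fold lower number from compound 2 to compound 3 (0.25 log units; that floor lies within the scatter), so this change has only a lower bound on its size, the real step could be larger, and the bound alone does not show a difference beyond ordinary repeat variation.

The compounds shown leave open how this place responds to other kinds of group, such as an amine, a carboxylic acid or a longer chain like ethoxy, any of which could read quite differently from methoxy and fluoro. A single pair also cannot say whether the same exchange would behave alike elsewhere on the ring or on a different core.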